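This account rests on a few compounds, and the source may have more. Where it says the series, first, only, none or still open, it means among the compounds named here.

In this assay, an ADME assay for permeability, using PAMPA, with a stated time of 30 min, at pH 7.4 (on this read-out lower numbers stand for lower permeability and higher numbers for higher permeability), compound 2 `c1ccc(Oc2ccc3c(NCCCNCc4ccco4)ccnc3c2)cc1` gives 317 10^-6 cm/s. Compound 1 `CC(C)(C)c1ccc(Oc2ccc3c(NCCCNCc4ccco4)ccnc3c2)cc1` gives 317 10^-6 cm/s, and the step of no change at the digits printed from compound 1 to compound 2 (within the scatter) shows that removing a tert-butyl left the read-out unchanged. Compound 3 `c1coc(CNCCCNc2ccnc3cc(-c4cccc5ccccc45)ccc23)c1` differs from compound 2 by naphthalen-1-yl in place of phenoxy on an aromatic carbon. Going by the values given here, only the step from compound 1 to compound 2 bears on this change, and it was within the scatter, so the expected step of a 1.1-fold lower number from compound 2 to compound 3 (0.02 log units; within the scatter) is none beyond the scatter. For compound 3 the estimated value is 300 10^-6 cm/s, with a range from 150 10^-6 cm/s to 450 10^-6 cm/s.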

Compound 3, apparent permeability: 237 10^-6 cm/s
Estimate against measurement, compound 3: 1.3-fold (0.10 log units) above, within the range that was stated.
By their numbers in this assay, from the lowest: compounds 3, 1 and 2 (each within the scatter of the next).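

In this assay, replacing the whole group at this aromatic carbon gives a 1.3-fold lower number from compound 2 to compound 3 (0.13 log units; within the scatter) and so stays within the scatter. The step from compound 1 to compound 2 removed only a tert-butyl, whereas here phenoxy, with its oxygen and single ring, gives way to naphthalen-1-yl, with two rings of carbon only. No measurement shown gives a reason for this result.
On these data alone, it remains open whether a group of a different kind at this position, such as an amine or a carboxylic acid, would also stay within the scatter.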